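Shifting a methyl group from compound 3 to compound 4

The compounds below may be only part of what the source reports. "The series", "measured", "known", "first", "only" and "open" are said of these compounds alone.

Within the data shown here, in a functional assay on MCF7 cells (Homo sapiens) for cytotoxicity, read by MTT assay, with a stated time of 72 h (a lower number here means a stronger inhibitor, a higher number a weaker inhibitor), compound 3 (`Cc1cccc(NC(=O)CSC(=S)N[C@H]2CCOC2=O)c1`) gives 63200 nM and compound 1 (`O=C(CSC(=S)N[C@H]1CCOC1=O)Nc1ccc(Cl)cc1`) gives 50300 nM as the only two actual numbers so far, and they lie within the scatter of each other. Compound 2 (`Cc1cccc(NC(=O)CSC(=S)N[C@H]2CCOC2=O)c1C`) reads > 128000 nM in this assay and this is a limit of the assay.

Compound 4 (`Cc1ccc(NC(=O)CSC(=S)N[C@H]2CCOC2=O)cc1`) differs from compound 3 by 4-methylphenyl in place of 3-methylphenyl on an amide-type nitrogen in one place: 4-methylphenyl in place of 3-methylphenyl on an amide-type nitrogen. Among the measured compounds shown here, two measured steps bear on this change. The closer one is a 1.3-fold higher number from compound 1 to compound 3 (0.10 log units; within the scatter) with 3-methylphenyl in place of 4-chlorophenyl on an amide-type nitrogen, the same place as the change at hand. The other is an at least 2.0-fold lower number from compound 2 to compound 3 (0.30 log units; that floor lies within the scatter) with hydrogen in place of methyl on an aromatic carbon, and it rests on a limit, so it gives only a floor. Given the step of a 1.3-fold higher number from compound 1 to compound 3 (0.10 log units; within the scatter) no shift beyond the scatter is expected in this assay for compound 4. The estimate amounts to a 1.1-fold lower number from compound 3 to compound 4 (0.02 log units; within the scatter) and so to no real change. Compound 4 is expected at 60000 nM with an estimated range from 28000 nM to 125000 nM in this assay once it is measured.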

Compound 4, half-maximal inhibitory concentration: 33500 nM
For compound 4 the middle estimate is 1.8-fold (0.25 log units) above the measured one; measured number inside the range.
By their numbers in this assay, from the lowest: compounds 4, 1 and 3 (each within the scatter of the next). At a limit, above all of these: compound 2.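

In this assay, among these compounds, moving the methyl group from 3-methylphenyl to 4-methylphenyl on the amide-type nitrogen gives a 1.9-fold lower number from compound 3 to compound 4 (0.28 log units; within the scatter) and so tests a second placement of the same group at this position for the first time, with no change beyond the scatter. Methyl in place of chloro on an aromatic carbon gives a 1.5-fold lower number from compound 1 to compound 4 (0.18 log units; within the scatter) and likewise stays within the scatter, so compounds 1, 3 and 4 cannot be told apart in this assay, and neither the placement of the methyl group nor the exchange with chloro separates them. Nothing shown here accounts for either step, and no measurement on these compounds gives a cause for where compound 4 falls.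

The compounds leave open whether any group on the phenyl ring can move the number beyond the scatter, for instance an amine or a carboxylic acid in place of the methyl group of 4-methylphenyl. They also leave open whether a longer chain, such as ethyl or propyl, would read any differently from methyl in this assay at this same position.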